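From 2-carboxyethyl to 2-carboxycyclopropyl in compound 1

The compounds below may be only part of what the source reports. "The series", "measured", "known", "first", "only" and "open" are said of these compounds alone.

Values in a physicochemical assay for lipophilicity, using the shake flask method, measured as octanol-water partition, with a stated time of 30 min, at pH 7.4 (a lower number here means a more polar compound, a higher number a more lipophilic compound), so far
Compound 1 `COc1nn(-c2ccccn2)c2cc(-c3ccc(CCC(=O)O)cc3)ccc12` gives 3.3
Compound 2 `CCc1nn(-c2ccccn2)c2cc(-c3ccc(CCC(=O)O)cc3)ccc12` gives 3.3
Compound 3 `N#Cc1nn(-c2ccccn2)c2cc(-c3ccc(CCC(=O)O)cc3)ccc12` gives 3

Compound 1 stands level with compound 2 at the digits shown, and compound 3 lies within the scatter of both. The compound still to be measured is compound 4 `COc1nn(-c2ccccn2)c2cc(-c3ccc([C@H]4C[C@@H]4C(=O)O)cc3)ccc12` with 2-carboxycyclopropyl in place of 2-carboxyethyl on an aromatic carbon and the rest of compound 1 unchanged.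

The measured steps exchange methoxy, ethyl and cyano on the shared core. They show no change at the digits printed from compound 1 to compound 2 (within the scatter) and a number 0.30 log units lower from compound 1 to compound 3 (within the scatter) and also a number 0.30 log units lower from compound 2 to compound 3 (within the scatter) in this assay for this series. Among the measured compounds shown here, none of them touches the 2-carboxyethyl group, so they offer only a gauge of how far the numbers have moved, and the data hold no direct precedent for the change at hand.

Taking compound 1 at 3.3 as the anchor, a small upward move is expected, probably not beyond the scatter. The expected change is a number 0.10 log units higher from compound 1 to compound 4 (within the scatter) and this remains an estimate. Compound 4 is estimated at 3.4 with 3 to 3.8 as the expected range.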

Compound 4, distribution coefficient: 3.8
Compound 4: the middle estimate sits 0.40 log units below what was measured; measured number inside the range.
By their numbers in this assay, from the lowest: compounds 3, 1 and 2 (each within the scatter of the next); then compound 4.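

In this assay, the exchange of 2-carboxyethyl for 2-carboxycyclopropyl, on an aromatic carbon of a six-membered aromatic ring of carbon only and para to a large group, gives a number 0.50 log units higher from compound 1 to compound 4 (beyond the scatter). Among the compounds shown here, this is the first step in the set to go beyond the scatter, since the exchanges among methoxy, ethyl and cyano on the shared core all stayed within it, and it shows that the number can respond to a change at this position. The change adds one carbon and a three-membered ring and also brings two defined stereocentres, and the data offer no measurement that accounts for the shift or separates these features.

Going by these compounds, only one stereochemical form of the 2-carboxycyclopropyl group appears here, so it remains open how its other forms would compare, and whether the same exchange would give a similar step with ethyl or cyano in place of methoxy. Also open, on these data alone, is how a cyclobutane ring or a longer chain carrying the acid would behave at this position.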